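A few compounds are considered here, and "the series" means these few. Any claim that something is new, unique, unknown or untested is made for them only; others in the source may bear on it.

Measured so far:
compound 1 `O=C(Nc1nc2ccc(F)cc2s1)c1cn(-c2ccccc2)nc1-c1ccccc1` — 5570 nM
compound 2 `COc1ccc2nc(NC(=O)c3cn(-c4ccccc4)nc3-c3ccccc3)sc2c1` — 40600 nM

In a functional assay on U-87MG ATCC cells for cytotoxicity against U-87 MG (Homo sapiens), read by MTT assay, with a stated time of 72 h (a lower number here means a stronger inhibitor, a higher number a weaker inhibitor), compound 1 gives the lower of the two numbers, and compound 2 stands apart from it: a 7.3-fold higher number from compound 1 to compound 2 (0.86 log units; beyond the scatter). Compound 3 `O=C(Nc1nc2ccc(F)cc2s1)c1cn(-c2ccccc2)nc1-c1ccc(F)cc1` differs from compound 1 by fluoro in place of hydrogen on an aromatic carbon. Among the compounds with values here, the single measured step concerns a different ring of the shared core, so no measured step bears directly on this change. The change is expected to give a step within the scatter, a 1.1-fold lower number from compound 1 to compound 3 (0.05 log units; within the scatter). Compound 3 is therefore estimated at 5000 nM, with a range from 2000 nM to 13000 nM.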

Compound 3, half-maximal inhibitory concentration: 12500 nM
Estimate against measurement, compound 3: 2.5-fold (0.40 log units) below, and the stated range covers the measured number.
By their numbers in this assay, from the lowest: compound 1; then compound 3; then compound 2.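

In this assay the change from phenyl to 4-fluorophenyl is not neutral, with a 2.2-fold higher number from compound 1 to compound 3 (0.35 log units; beyond the scatter) as the step, so this ring of the shared core also moves the number, which the earlier step on a different ring could not show. Both single changes from compound 1 now raise the number. No measured finding explains this step.

Open, going by these compounds, is whether the rise is specific to fluoro or would follow any group on this carbon. A chloro, methoxy or amine at the same place would separate these readings.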